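The source may hold more compounds than are shown below. What is called first, only, known or untested is meant among the compounds shown, and "the series" means these compounds.

Measured compounds:
Compound 1, `NC(=O)c1cn(Cc2nnc(-c3cc(S(N)(=O)=O)c(SCc4ccccc4)cc3Cl)o2)nn1`, gives 75000 nM in a functional assay on HeLa cells (Homo sapiens) for cytotoxicity, read by MTT assay, with a stated time of 72 h; a lower number here means a stronger inhibitor, a higher number a weaker inhibitor.
Compound 2, `NS(=O)(=O)c1cc(-c2nnc(CNC(=O)c3ccccc3)o2)c(Cl)cc1SCc1ccccc1`, gives 105000 nM in this assay.
Compound 3, `NS(=O)(=O)c1cc(-c2nnc(/C=C/c3ccccc3)o2)c(Cl)cc1SCc1ccccc1`, gives 14000 nM in this assay.

Compound 3 holds the lowest number of the three. Its distance from the others is set out by a 5.4-fold lower number from compound 1 to compound 3 (0.73 log units; beyond the scatter) and a 7.5-fold lower number from compound 2 to compound 3 (0.88 log units; beyond the scatter), both beyond the scatter, while the step of a 1.4-fold higher number from compound 1 to compound 2 (0.15 log units; within the scatter) lies within it. All three measured steps concern the group attached to the shared core on the side away from the sulfonamide and benzylthio groups.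

Compound 4, `NS(=O)(=O)c1cc(-c2nnc(/C=C/c3ccc(Cl)cc3)o2)c(Cl)cc1SCc1ccccc1`, differs from compound 3 by chloro in place of hydrogen on an aromatic carbon. Among the measured compounds shown here, none of the measured steps changes this six-membered ring, so no measured step bears directly on the change; they only show that altering the far side of the core can move the number by a modest amount. A single chloro added to that ring is a smaller alteration than any of them. The step of a 1.3-fold lower number from compound 3 to compound 4 (0.10 log units; within the scatter) is therefore expected to fall within the scatter, with no clear direction. Compound 4 is estimated to give about 11000 nM in this assay, ranging from 3500 nM to 35000 nM.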

Compound 4, half-maximal inhibitory concentration: 40000 nM
Compound 4: the middle estimate sits 3.6-fold (0.56 log units) below what was measured; measured number outside the range, above it.
By their numbers in this assay, from the lowest: compound 3; then compounds 4, 1 and 2 (each within the scatter of the next, the first and the last beyond it).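

In this assay, compound 4 gives the only reading shown for a change on the phenyl ring of the 2-phenylethenyl group, and a 2.9-fold higher number from compound 3 to compound 4 (0.46 log units; beyond the scatter) shows that this ring is not indifferent: chloro in place of hydrogen, para to a large group, raises the number beyond the scatter. The 2-(4-chlorophenyl)ethenyl group still keeps some advantage over benzamidomethyl, with a 2.6-fold lower number from compound 2 to compound 4 (0.42 log units; beyond the scatter), but with a 1.9-fold lower number from compound 1 to compound 4 (0.27 log units; within the scatter) it no longer stands apart from (4-carbamoyl-1H-1,2,3-triazol-1-yl)methyl, as 2-phenylethenyl did. Nothing available accounts for this shift.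

As far as these compounds go, whether the rise is peculiar to chloro or would also follow from fluoro, methyl, methoxy or an amine at this place stays open. So does whether chloro elsewhere on this ring would move the number the same way.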